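Varying the amine on the shared core of compound 2

The source may hold more compounds than are shown below. What is called first, only, known or untested is meant among the compounds shown, and "the series" means these compounds.

Measured compounds:
compound 1 `Cc1ccc(S(=O)(=O)Nc2ccc(CNc3nc(N(C)C)nc4ccccc34)cc2)cc1` gives 11000 nM
compound 2 `CN(C)c1nc(NCc2ccc(NC(=O)c3ccncc3)cc2)c2ccccc2n1` gives 15000 nM
compound 3 `CN(C)c1nc(NCc2ccc(C(=O)Nc3ccc(F)cc3)cc2)c2ccccc2n1` gives 1900 nM

In a functional assay on HCT-116 cells (Homo sapiens) for inhibition, read by luminescence and resazurin assay, with a stated time of 3 days (on this read-out lower numbers stand for stronger inhibition and higher numbers for weaker inhibition), compound 2 gives the highest of the three numbers. Its nearest neighbour is compound 1, a step of a 1.4-fold higher number from compound 1 to compound 2 (0.13 log units; within the scatter), and the furthest is compound 3, reached by a 7.9-fold lower number from compound 2 to compound 3 (0.90 log units; beyond the scatter). Both of those steps alter the group on the far end of the molecule, away from the core.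

Compound 4 `CNc1nc(NCc2ccc(NC(=O)c3ccncc3)cc2)c2ccccc2n1` differs from compound 2 in another place entirely: hydrogen in place of methyl on a nitrogen on an aromatic ring, which, cut one bond further out, reads dimethylamino to methylamino. For the measured compounds named here, none of the measured steps touches this nitrogen, so nothing in the data shows what such a change does in this assay. Going by the values given here, with no step bearing on it, the expectation is a change no larger than the scatter, in no stated direction, so no change at the digits printed from compound 2 to compound 4 (within the scatter) is the estimated step. Compound 4 is therefore expected to give about 15000 nM, with a range from 5000 nM to 45000 nM.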

Compound 4, half-maximal inhibitory concentration: > 20000 nM
Compound 4 gave a limit, no number (the forecaster's own chance of this, stated with the estimate: 20%); at least 1.3-fold (0.12 log units) between middle value and limit.
By their numbers in this assay, from the lowest: compound 3; then compounds 1 and 2 (each within the scatter of the next). At a limit, above all of these: compound 4.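

Compound 4 gives > 20000 nM in this assay, which is a limit of the assay and not a number. The earlier steps shown here changed only the far end of the molecule, whereas this one shows that the dimethylamino group can lose a methyl with no gain in inhibition: the change gives an at least 1.3-fold higher number from compound 2 to compound 4 (0.12 log units; that floor lies within the scatter), so a real loss is possible but not established, as the floor of this step lies within the scatter. The size of the step therefore stays unknown, and the reading stops at the assay's ceiling: the limit of > 20000 nM in this assay, at which 1 of the 4 values shown sits.

Still open, as far as these compounds go, is how a free amino group, a diethylamino group or a morpholine on this carbon of the core would read. Also open, from the compounds shown here alone, is what dimethylamino to methylamino does on the framework of compound 3, which gives 1900 nM.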